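A tert-butyl swap at the limit of the assay

The source may hold more compounds than are shown below. What is called first, only, known or untested is meant among the compounds shown, and "the series" means these compounds.

In an ADME assay on Raji cells (Homo sapiens) for cytotoxicity, with a stated time of 72 h (a lower number here means that less compound is needed, a higher number that more compound is needed for the effect), compound 1 `Cc1cc(NC(=O)Nc2ccccc2OC(F)(F)F)c2ccccc2n1` gives > 25000 nM as a limit, not a number. Compound 2 `Cc1cc(NC(=O)Nc2ccccc2N)c2ccccc2n1` gives > 25000 nM in this assay as a limit too. The data so far show the limit of > 25000 nM in this assay, at which 2 of the 2 values shown sit, and no readable number. Compound 3 `Cc1cc(NC(=O)Nc2ccccc2C(C)(C)C)c2ccccc2n1` carries tert-butyl in place of amino on an aromatic carbon. Going by the values given here, the one measured step that the two limits leave unreadable from compound 1 to compound 2 has no size to carry over, so no readable shift is expected in this assay and no direction can be claimed. The estimated step is a number no higher from compound 2 to compound 3 (the limit leaves the size open) on this slim basis. Compound 3 is expected at 25000 nM (estimated range 8000 nM to 60000 nM).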

Compound 3, half-maximal effective concentration: > 25000 nM
Compound 3 gave a limit, no number (the forecaster's own chance of this, stated with the estimate: 80%); the middle value lies on the limit itself.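

No new step can be read between compound 1, compound 2 and compound 3, because each value is a limit and not a number: the limit of > 25000 nM in this assay, at which 3 of the 3 values shown sit.

From the compounds shown here alone, how trifluoromethoxy, amino and tert-butyl compare in this assay stays open.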